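A few compounds are considered here, and "the series" means these few. Any claim that something is new, unique, unknown or untested is made for them only; others in the source may bear on it.

Of the compounds shown here, two with a shared core have been tested in a functional assay on HEK293 cells for agonist activity at trace amine-associated receptor 1 (Homo sapiens), read by cAMP accumulation, with a stated time of 30 min; on this read-out higher numbers stand for larger maximal responses and lower numbers for smaller maximal responses. Compound 1 `CCN(C[C@@H]1COC(N)=N1)c1ccccc1` gives 94% in this assay. Compound 2 `CC(C)N(C[C@H]1COC(N)=N1)c1ccccc1` gives 58% in this assay, which is the lowest of the two numbers; its nearest neighbour is compound 1, and the gap between them is larger than the usual scatter of repeated measurements.

The next compound, compound 3 `CCN(C[C@H]1COC(N)=N1)c1ccccc1`, has not yet been measured in this assay. It differs from compound 2 in one place: hydrogen in place of methyl on a saturated chain carbon bound to a nitrogen on an aromatic ring and a saturated chain carbon. The change is a small one, and it makes the chain on the nitrogen match the ethyl chain found in compound 1.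

Among the compounds with values here, no measured pair in this set shows the effect of this exact change, so the expectation rests on the two numbers in hand. Because compound 1 gives 94% with an ethyl chain, a move upward from compound 2 seems the more likely direction, and the step from compound 2 to compound 3 is estimated at a number 18 percentage points higher from compound 2 to compound 3 (beyond the scatter) in this assay. Compound 3 is therefore expected to reach about 76% in this assay, with a likely range from 52% to 100%.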

Compound 3, largest response reached (Emax), in percent of the reference or control that the assay uses: 87%
Compound 3: middle estimate off by 11 percentage points, on the low side, and the stated range covers the measured number.
By their numbers in this assay, from the lowest: compound 2; then compounds 3 and 1 (each within the scatter of the next).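

Compounds 1 and 2 differ in two places at once, whereas compound 3 separates those differences and allows each to be read alone. With the drawn configuration held the same, going from isopropyl to ethyl gives a number 29 percentage points higher from compound 2 to compound 3 (beyond the scatter) in this assay and shows that the maximal response depends on which of these two chains is present at this place. The other step gives a number 7 percentage points lower from compound 1 to compound 3 (within the scatter) and so, with the ethyl chain in place, reversing the stereocentre at the saturated ring carbon leaves the two numbers within the usual scatter, a reading that rests on a single pair with one clean difference: the fact that compounds 1 and 3 differ only in the configuration as drawn.

The compounds shown leave open how a methyl group or a longer chain such as propyl would read in place of the ethyl chain, so only two points on this series of chains are known. They also leave open whether the stereocentre would count as little with the isopropyl chain as it does with ethyl, and the pair of ethyl compounds cannot settle that question.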